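Shared core anilines: tetrafluoroethoxy in place of ethyl

The source may hold more compounds than are shown below. What is called first, only, known or untested is meant among the compounds shown, and "the series" means these compounds.

Measured so far in an assay on mitochondria from L6 cells (Rattus norvegicus) for activation, with a stated time of 90 min; a higher number here means that more compound is needed for the effect, a lower number that less compound is needed:
Compound 1, `Cc1cccc(C)c1Nc1nc2nonc2nc1O`: the value is a limit of the assay, > 100000 nM.
Compound 2, `CCc1ccc(Nc2nc3nonc3nc2O)cc1`: 10700 nM.
Compound 3, `CCc1ccc(Nc2nc3nonc3nc2O)c(F)c1`: 6700 nM.

Among the measured compounds shown here, compound 2 and compound 3 are the only two compounds with a number rather than a limit, and their values sit within the scatter of each other: a 1.6-fold lower number from compound 2 to compound 3 (0.20 log units; within the scatter), with fluoro in place of hydrogen on an aromatic carbon. Compound 1 stands apart only as a limit.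

Compound 4, `Oc1nc2nonc2nc1Nc1ccc(OC(F)(F)C(F)F)cc1`, differs from compound 2 by 1,1,2,2-tetrafluoroethoxy in place of ethyl on an aromatic carbon. For the measured compounds named here, no measured step bears directly on this change; the one measured step, a 1.6-fold lower number from compound 2 to compound 3 (0.20 log units; within the scatter), also alters the aryl ring and stays within scatter. On that basis the expectation for compound 4 in this assay is a number close to compound 2, with the step of a 1.3-fold lower number from compound 2 to compound 4 (0.13 log units; within the scatter) expected to stay within scatter. Compound 4 is estimated at 8000 nM, in a range from 2500 nM to 25000 nM.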

Compound 4, half-maximal effective concentration: 7000 nM
The estimate for compound 4 lay 1.1-fold (0.06 log units) above the measured number; the range from low to high includes it.
By their numbers in this assay, from the lowest: compounds 3, 4 and 2 (each within the scatter of the next). At a limit, above all of these: compound 1.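

In this assay, 1,1,2,2-tetrafluoroethoxy in place of ethyl, on an aromatic carbon para to a large group, gives a 1.5-fold lower number from compound 2 to compound 4 (0.18 log units; within the scatter). This is the first change shown at this position, and it shows that a much larger group, one that brings a hydrogen-bond acceptor and fluorine where ethyl has neither, leaves the number within the scatter. Nothing at hand bears on why the number holds across this change.

As far as these compounds go, whether an amine, a carboxylic acid or a longer alkyl chain at this position would move the number beyond the scatter remains open. Also open, from the compounds shown here alone, is whether the fluoro of compound 3 and the 1,1,2,2-tetrafluoroethoxy of compound 4, placed together on one ring, would give a number apart from either compound.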